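A few compounds are considered here, and "the series" means these few. Any claim that something is new, unique, unknown or untested is made for them only; others in the source may bear on it.

Going by the values given here, in a functional assay on LNCaP cells (Homo sapiens) for inhibition, read by MTT assay (on this read-out higher numbers stand for weaker inhibition of growth and lower numbers for stronger inhibition of growth), three compounds that share one core have numbers so far. Compound 1 `CC1=C(/C=C/C(C)=C/C=C/C(C)=C\C(=O)Nc2ccc(O)cc2)C(C)(C)CCC1n1ccnc1` gives 3540 nM, compound 2 `CC1=C(/C=C/C(C)=C/C=C/C(C)=C\C(=O)Nc2cccc(F)c2)C(C)(C)CCC1n1ccnc1` gives 2690 nM, and compound 3 `CC1=C(/C=C/C(C)=C/C=C/C(C)=C\C(=O)NCc2ccc(O)cc2)C(C)(C)CCC1n1ccnc1` gives 1690 nM. Compound 3 stands clearly apart from only one of the others: the data show a 2.1-fold lower number from compound 1 to compound 3 (0.32 log units; beyond the scatter), but also a 1.6-fold lower number from compound 2 to compound 3 (0.20 log units; within the scatter).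

The next structure is compound 4 `CC1=C(/C=C/C(C)=C/C=C/C(C)=C\C(=O)Nc2ccccc2O)C(C)(C)CCC1n1ccnc1`, where 2-hydroxyphenyl replaces 4-hydroxybenzyl on an amide-type nitrogen: 2-hydroxyphenyl in place of 4-hydroxybenzyl on an amide-type nitrogen. Among the compounds with values here, no measured compound carries 2-hydroxyphenyl, so the nearest guides are compound 1, with 4-hydroxyphenyl, and compound 2, with 3-fluorophenyl. Those two groups differ little, with a 1.3-fold lower number from compound 1 to compound 2 (0.12 log units; within the scatter). The move from compound 1 to the 4-hydroxybenzyl group of compound 3 was modest, and reversing that kind of change suggests a small rise in the number. The expected step is a 1.8-fold higher number from compound 3 to compound 4 (0.25 log units; within the scatter). For compound 4 the estimated value is 3000 nM, with an expected range from 1500 nM to 6000 nM.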

Compound 4, concentration for 50% growth inhibition: 3230 nM
The estimate for compound 4 lay 1.1-fold (0.03 log units) below the measured number; the range from low to high includes it.
By their numbers in this assay, from the lowest: compounds 3, 2, 4 and 1 (each within the scatter of the next, the first and the last beyond it).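

In this assay, 2-hydroxyphenyl in place of 4-hydroxyphenyl on the amide-type nitrogen gives a 1.1-fold lower number from compound 1 to compound 4 (0.04 log units; within the scatter), so shifting the hydroxyl makes no readable difference here, and the comparison with 3-fluorophenyl, a 1.2-fold higher number from compound 2 to compound 4 (0.08 log units; within the scatter), likewise shows none. The 4-hydroxybenzyl group stood clear of 4-hydroxyphenyl, yet a 1.9-fold higher number from compound 3 to compound 4 (0.28 log units; within the scatter) stays inside the scatter, so that separation is not repeated against 2-hydroxyphenyl and still rests on a single comparison. No measurement at hand explains any of these numbers.

Still open, going by these compounds, is whether 2-hydroxybenzyl would give a number like that of 4-hydroxybenzyl, as the benzyl group appears here with only one hydroxyl placement. Also open, on these data alone, is whether an amine or a carboxylic acid on the ring, or a longer chain such as 2-(4-hydroxyphenyl)ethyl, would produce a step beyond the scatter.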